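The source may hold more compounds than are shown below. What is called first, only, known or untested is meant among the compounds shown, and "the series" means these compounds.

Compound 1 `CN1C(=O)[C@@]2(c3ccccc31)N(C)C[C@@H](c1ccco1)[C@@]21Cc2ccccc2C1=O` and compound 2 `CN1C[C@@H](c2ccco2)[C@@]2(Cc3ccccc3C2=O)[C@@]12C(=O)Nc1ccccc12` share one core and differ only in hydrogen in place of methyl on an amide-type nitrogen in a ring. In a functional assay on the whole organism (strain Wister albino) for inhibition, with Rattus norvegicus as the target, read by paw edema, with stated times of 1 h and 3 h, at a dose of 50 mg/kg by the intraperitoneal route (on this read-out higher numbers stand for more inhibition at the one dose given (going by the name of the read-out) and lower numbers for less inhibition), compound 1 gives 17.5%, and compound 2 gives 38.8%. Compound 1 thus stands lowest of the two numbers, its nearest neighbour being compound 2, the step being a number 21.3 percentage points higher from compound 1 to compound 2 (beyond the scatter).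

Compound 3 `CN1C(=O)[C@@]2(c3ccccc31)N(C)C[C@@H](c1cccs1)[C@@]21Cc2ccccc2C1=O` keeps the methyl on the amide-type nitrogen of compound 1 and alters the five-membered aromatic ring instead: thiophen-2-yl in place of furan-2-yl on a saturated ring carbon. Among the compounds with values here, no measured step bears on this change; the one step in hand, from compound 1 to compound 2, concerns the amide-type nitrogen and gives no guide to an exchange of furan-2-yl for thiophen-2-yl. With only the number for compound 1 to anchor it, the expected step is a number 2.5 percentage points higher from compound 1 to compound 3 (within the scatter), that is, none beyond the scatter. Compound 3 is therefore estimated at 20%, within a range of 5% to 35%.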

Compound 3, a percentage reported as inhibition, in the whole organism at one dose (the size of the read-out at that dose, not a potency): 9.1%
Compound 3: the middle estimate sits 10.9 percentage points above what was measured; the measured number falls inside the stated range.
By their numbers in this assay, from the lowest: compounds 3 and 1 (each within the scatter of the next); then compound 2.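

With the methyl kept on the amide-type nitrogen, thiophen-2-yl in place of furan-2-yl on the saturated ring carbon gives, in this assay, a number 8.4 percentage points lower from compound 1 to compound 3 (within the scatter). Within the data shown here, this is the first reading at this position, and in this pair the exchange of the five-membered aromatic ring does not separate the two compounds, whereas a number 21.3 percentage points higher from compound 1 to compound 2 (beyond the scatter) at the amide-type nitrogen remains the only step beyond the scatter. No measurement in hand accounts for this result or links it to any property of either ring.

Going by these compounds, whether the exchange of furan-2-yl for thiophen-2-yl would read the same with hydrogen on the amide-type nitrogen, as in compound 2, remains open. Also open, on these data alone, is how a phenyl ring, an amine or a longer alkyl chain would read on the same ring carbon.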